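Swapping an Indole for a Methylsulfonylphenyl Group

The source may report more compounds than this note shows. Statements on the series, on what has been measured and on what is new or still open speak of the compounds shown alone.

Of the compounds shown here, two sharing one core have been tested in an ADME assay on Raji cells (Homo sapiens) for cytotoxicity, read by CellTiter-Glo and resazurin assay, with a stated time of 72 h; a higher number here means that more compound is needed for the effect, a lower number that less compound is needed. Compound 1 `CCOC(=O)CCCCCOc1cccc(CN(C(=O)c2ccc(-c3cccc4ccccc34)cc2)C(C)C)c1` carries a naphthalen-1-yl group, and in this assay compound 1 gives > 26000 nM, which is a limit of the assay and not a number. Compound 2 `CCOC(=O)CCCCCOc1cccc(CN(C(=O)c2ccc(-c3ccc4[nH]ccc4c3)cc2)C(C)C)c1` carries a 1H-indol-5-yl group in its place, and in this assay compound 2 gives > 26000 nM, again a limit of the assay rather than a number. The step that the two limits leave unreadable from compound 1 to compound 2 cannot be read because both values sit at the limit (the limit of > 26000 nM in this assay, at which 2 of the 2 values shown sit). Compound 2 therefore stands at the limit, with no number beneath it.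

Compound 3 `CCOC(=O)CCCCCOc1cccc(CN(C(=O)c2ccc(-c3cccc(S(C)(=O)=O)c3)cc2)C(C)C)c1` introduces the next change: 3-(methylsulfonyl)phenyl in place of 1H-indol-5-yl on an aromatic carbon. Going by the values given here, the only measured step is unreadable, so no measured size bears on this change. Nothing in the two measured compounds shows a change at this position bringing the readout into the measurable range, so compound 3 is expected to remain near the limit as well, and the expected step of a number no higher from compound 2 to compound 3 (the limit leaves the size open) is small. Compound 3 is estimated at 26000 nM, within a range from 10000 nM to 60000 nM.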

Compound 3, half-maximal effective concentration: > 26000 nM
Compound 3 was reported as a limit; the forecaster's own chance of this, stated with the estimate: 80%; the middle value sits exactly at the limit.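

No step between compound 1, compound 2 and compound 3 can be read in this assay, because each value is a limit of the assay and not a number: the limit of > 26000 nM in this assay, at which 3 of the 3 values shown sit.

The compounds leave open how much of each is needed for the effect, and whether the naphthalen-1-yl, 1H-indol-5-yl and 3-(methylsulfonyl)phenyl groups differ at all in this respect.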